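A few compounds are considered here, and "the series" means these few. Any claim that something is new, unique, unknown or untested is made for them only; others in the source may bear on it.

For the measured compounds named here, in a functional assay on PC-3 cells (Homo sapiens) for cytotoxicity, read by MTT assay, with a stated time of 48 h (a lower number here means a stronger inhibitor, a higher number a weaker inhibitor), compound 1 `COc1cccc(OC)c1/C=C/[C@](C)(O)CC[C@@H]1[C@@]2(C)CCCC(C)(C)[C@@H]2CC[C@@]1(C)O` gives 4000 nM and compound 2 `Cc1cccc(/C=C/[C@](C)(O)CC[C@@H]2[C@@]3(C)CCCC(C)(C)[C@@H]3CC[C@@]2(C)O)c1C` gives 3500 nM, so compound 2 stands level with the only other measured compound. Compound 3 `CC(C)(C)c1ccc(/C=C/[C@](C)(O)CC[C@@H]2[C@@]3(C)CCCC(C)(C)[C@@H]3CC[C@@]2(C)O)cc1` keeps the shared core and alters one group: 4-(tert-butyl)phenyl in place of 2,3-dimethylphenyl on a double-bonded chain carbon bound to a double-bonded chain carbon. In words, 4-(tert-butyl)phenyl comes in place of 2,3-dimethylphenyl on a double-bonded chain carbon bound to a double-bonded chain carbon. Going by the values given here, one measured step bears on this change, a 1.1-fold lower number from compound 1 to compound 2 (0.06 log units; within the scatter), which exchanged the group at that same place. Neither measured compound carries 4-(tert-butyl)phenyl, so this single step is only a thin guide. With a 1.1-fold lower number from compound 1 to compound 2 (0.06 log units; within the scatter) as that guide, no change beyond the scatter is expected, in either direction. The expected step is no change at the digits printed from compound 2 to compound 3 (within the scatter). For compound 3, the estimate is 3500 nM, with an expected range from 1500 nM to 8000 nM.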

Compound 3, half-maximal inhibitory concentration: 3800 nM
Compound 3: the middle estimate sits 1.1-fold (0.04 log units) below what was measured, and the stated range covers the measured number.
By their numbers in this assay, from the lowest: compounds 2, 3 and 1 (each within the scatter of the next).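

In this assay the exchange of 2,3-dimethylphenyl for 4-(tert-butyl)phenyl stays within the scatter (a 1.1-fold higher number from compound 2 to compound 3 (0.04 log units; within the scatter)), and the comparison with the 2,6-dimethoxyphenyl compound also stays within the scatter (a 1.1-fold lower number from compound 1 to compound 3 (0.02 log units; within the scatter)). For the compounds shown here, the earlier pair showed only two rings with neighbouring numbers, whereas three differently substituted phenyl rings on a double-bonded chain carbon bound to a double-bonded chain carbon now read as level, including one whose substituent pattern differs from both earlier rings. No supporting evidence accompanies these numbers to explain this sameness.

Only phenyl rings carrying methyl, methoxy or tert-butyl groups appear at this place. As far as these compounds go, whether an amine or a carboxylic acid on the ring, or a pyridine ring in place of the phenyl, would shift the number beyond the scatter remains open.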